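The compounds below may be only part of what the source reports. "The series", "measured", "known", "first", "only" and "open" are said of these compounds alone.

The series rests on three measured compounds and a fourth still to be measured. Compound 1 `Oc1ccc(-c2cc(-c3ccccc3C(F)(F)F)cc(-c3ccccc3O)n2)cc1` gives 7180 nM in a functional assay on T47D cells (Homo sapiens) for inhibition; on this read-out higher numbers stand for weaker inhibition and lower numbers for stronger inhibition. Compound 2 `Oc1ccc(-c2cc(-c3cccc(C(F)(F)F)c3)cc(-c3ccccc3O)n2)cc1` reaches only the limit of this assay, recorded as > 50000 nM, which is a limit rather than a number. Compound 3 `Oc1ccc(-c2cc(-c3ccccc3C(F)(F)F)cc(-c3cccc(O)c3)n2)cc1` gives 3210 nM in this assay , the lowest of the two numbers, with compound 1 nearest to it.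

Among the compounds with values here, the change from compound 1 to compound 2 is 3-(trifluoromethyl)phenyl in place of 2-(trifluoromethyl)phenyl on an aromatic carbon, and it gave an at least 6.9-fold higher number from compound 1 to compound 2 (0.84 log units; beyond the scatter); the limit itself is the only evidence on this step: the limit of > 50000 nM in this assay, at which 1 of the 3 values shown sits. The cores of compound 1 and compound 3 differ by 3-hydroxyphenyl in place of 2-hydroxyphenyl on an aromatic carbon, which gave a 2.2-fold lower number from compound 1 to compound 3 (0.35 log units; beyond the scatter).

Compound 4 `Oc1ccc(-c2cc(-c3cccc(C(F)(F)F)c3)cc(-c3cccc(O)c3)n2)cc1` is not yet measured in this assay . It arises from compound 3 by 3-(trifluoromethyl)phenyl in place of 2-(trifluoromethyl)phenyl on an aromatic carbon. Within the data shown here, this is the same kind of change as the one from compound 1 to compound 2, though not the same: in compound 1 it sits meta to a 2-hydroxyphenyl group, in compound 3 meta to a 3-hydroxyphenyl group. Because of an at least 6.9-fold higher number from compound 1 to compound 2 (0.84 log units; beyond the scatter), the step from compound 3 to compound 4 is expected to be a 9.3-fold higher number from compound 3 to compound 4 (0.97 log units; beyond the scatter), with a real chance that only a limit is returned. Compound 4 is therefore estimated at 30000 nM, and the number is expected to lie between 12000 nM and 80000 nM.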

Compound 4, half-maximal inhibitory concentration: 2630 nM
Beside the measured number, compound 4's estimate is 11-fold (1.06 log units) above it; the measured number lies below the stated range.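

On the core of compound 3, 3-(trifluoromethyl)phenyl in place of 2-(trifluoromethyl)phenyl gave a 1.2-fold lower number from compound 3 to compound 4 (0.09 log units; within the scatter), so in this assay this change did not carry over from the core of compound 1: the same change on two cores in this assay, an at least 6.9-fold higher number (0.84 log units; beyond the scatter) from compound 1 to compound 2 and a 1.2-fold lower number (0.09 log units; within the scatter) from compound 3 to compound 4, at least 8.4-fold (0.92 log units) apart, beyond the scatter of two such steps

Seen from the other side, 3-hydroxyphenyl in place of 2-hydroxyphenyl gave an at least 19-fold lower number from compound 2 to compound 4 (1.27 log units; beyond the scatter), which points the same way as the step from compound 1 to compound 3 but differs from it in size: the same change on two cores in this assay, a 2.2-fold lower number (0.35 log units; beyond the scatter) from compound 1 to compound 3 and an at least 19-fold lower number (1.27 log units; beyond the scatter) from compound 2 to compound 4, at least 8.4-fold (0.92 log units) apart, beyond the scatter of two such steps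

Compound 2 is recorded at a limit and not at a number, so both gaps are known only as bounds, and they do not show why the two cores respond differently: the limit of > 50000 nM in this assay, at which 1 of the 4 values shown sits.

Going by these compounds, all four compounds keep the 4-hydroxyphenyl group in place, so it stays open whether the values of compound 3 and compound 4 would hold if that group gave way to an aminophenyl or a carboxyphenyl group. On these data alone, it is also open whether a nitrile in place of the trifluoromethyl group would depend on the hydroxyphenyl group in the same way.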